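Notes: butyl to benzyl, compound 3 to compound 4

The source may report more compounds than this note shows. Statements on the series, on what has been measured and on what is new or still open speak of the compounds shown alone.

Measured in a functional assay on NCI-H460 cells (Homo sapiens) for antiproliferative activity, read by MTT assay, with a stated time of 48 h; on this read-out lower numbers stand for stronger inhibition and higher numbers for weaker inhibition:
compound 1 `COc1ccc(Nc2ccc3c(c2)C(O)(Cc2ccccc2)C(=O)N3)cc1`: > 100000 nM (a limit, not a number)
compound 2 `Cc1ccc(Nc2ccc3c(c2)C(O)(Cc2ccccc2)C(=O)N3)cc1`: 31600 nM
compound 3 `CCCCC1(O)C(=O)Nc2ccc(Nc3ccc(C(F)(F)F)cc3)cc21`: 12000 nM

Compound 3 at 12000 nM has the lower of the two true numbers, and the gap to compound 2 at 31600 nM lies beyond the scatter. The value of compound 1 is only a limit.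

Compound 4 `O=C1Nc2ccc(Nc3ccc(C(F)(F)F)cc3)cc2C1(O)Cc1ccccc1` differs from compound 3 by one change: phenyl in place of propyl on a saturated chain carbon bound to a saturated ring carbon. This is phenyl in place of propyl on a saturated chain carbon bound to a saturated ring carbon, or butyl to benzyl when cut one bond further out.

For the measured compounds named here, no measured step changes this chain. Going by the values given here, the one measured step, an at least 3.1-fold lower number from compound 1 to compound 2 (0.50 log units; beyond the scatter), is methyl in place of methoxy on an aromatic carbon, so it bears only indirectly. The benzyl of compound 4 also sits on compound 2, which gives 31600 nM.

Among the compounds with values here, with no direct precedent, the expected step in this assay is none beyond the scatter, in either direction: no change at the digits printed from compound 3 to compound 4 (within the scatter). For compound 4 the estimated value is 12000 nM, with an expected range of 4000 nM to 36000 nM.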

Compound 4, half-maximal inhibitory concentration: 9100 nM
Compound 4: middle estimate off by 1.3-fold (0.12 log units), on the high side, and the stated range covers the measured number.
By their numbers in this assay, from the lowest: compounds 4 and 3 (each within the scatter of the next); then compound 2. At a limit, above all of these: compound 1.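

In this assay, with trifluoromethyl held constant, the chain can carry an aromatic ring without a shift beyond the scatter: a 1.3-fold lower number from compound 3 to compound 4 (0.12 log units; within the scatter). With benzyl held constant, the group on the aromatic carbon now has measured steps against trifluoromethyl, a 3.5-fold lower number from compound 2 to compound 4 (0.54 log units; beyond the scatter) for trifluoromethyl in place of methyl and an at least 10-fold lower number from compound 1 to compound 4 (1.04 log units; beyond the scatter) for trifluoromethyl in place of methoxy. The last step rests on compound 1, whose value is a limit and not a number: the limit of > 100000 nM in this assay, at which 1 of the 4 values shown sits.

On these data alone, whether these trifluoromethyl steps also hold with butyl on the shared core remains open. As far as these compounds go, the effects of a nitrile on that aromatic carbon, and of a longer chain or a chain ending in a carboxylic acid in place of butyl or benzyl, are also open.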